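Formyl in Place of Ethyl: Expected Loss of Inhibition

The source may hold more compounds than are shown below. What is called first, only, known or untested is meant among the compounds shown, and "the series" means these compounds.

Three compounds were measured in a functional assay on SK-MEL-28 cells (Homo sapiens) for inhibition, read by sulforhodamine B assay, with a stated time of 48 h, tested at 10 uM; on this read-out higher numbers stand for more inhibition at the one concentration tested (going by the name of the read-out) and lower numbers for less inhibition:
compound 1 `c1ccc(-c2cn3ccnc3c(-c3ccc4ncn(C5CCCCC5)c4c3)n2)cc1` gave 18%;
compound 2 `O=Cc1ccc(-c2cn3ccnc3c(-c3ccc4ncn(C5CCCCC5)c4c3)n2)cc1` gave 7.54%;
compound 3 `CCc1ccc(-c2cn3ccnc3c(-c3ccc4ncn(Cc5ccccc5)c4c3)n2)cc1` gave 19.1%.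

Compound 3 gives the highest of the three numbers, but its gap to compound 1 lies within the scatter, so those two cannot be ordered; only compound 2 sits clearly lower than compound 3. Compound 4 `O=Cc1ccc(-c2cn3ccnc3c(-c3ccc4ncn(Cc5ccccc5)c4c3)n2)cc1` differs from compound 3 in one place: formyl in place of ethyl on an aromatic carbon. Within the data shown here, one measured step bears on this change. Formyl in place of hydrogen on an aromatic carbon gave a number 10.5 percentage points lower from compound 1 to compound 2 (beyond the scatter). The change from compound 3 to compound 4 also brings formyl onto an aromatic carbon, though here it replaces ethyl rather than hydrogen, and the two compounds differ from compounds 1 and 2 elsewhere in the shared core. With that single step as the guide, a drop beyond the scatter is expected, and the step expected in this assay is a number 11.1 percentage points lower from compound 3 to compound 4 (beyond the scatter). The estimate for compound 4 is 8%, with a range from 0% to 18%.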

Compound 4, a percentage reported as inhibition, at one concentration (the size of the read-out at that concentration, not a potency): 7.54%
Beside the measured number, compound 4's estimate is 0.5 percentage points above it, within the range that was stated.
By their numbers in this assay, from the lowest: compounds 2 and 4 (each within the scatter of the next); then compounds 1 and 3 (each within the scatter of the next).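

In this assay, the change from 4-ethylphenyl to 4-formylphenyl gave a number 11.6 percentage points lower from compound 3 to compound 4 (beyond the scatter). Formyl at this place, para to a large group, therefore goes with a lower number when it replaces ethyl on a benzyl compound, as well as when it replaces hydrogen on a cyclohexyl compound. With formyl held in place, benzyl in place of cyclohexyl on the aromatic nitrogen gave no change at the digits printed from compound 2 to compound 4 (within the scatter), so this swap left the reading unmoved in this pair. Nothing available explains the lower numbers that come with formyl.

Going by these compounds, whether this drop is particular to formyl remains open, since a carboxylic acid, a hydroxymethyl group or an amine on the same aromatic carbon could read differently. A single concentration also leaves open how these compounds would rank in potency.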